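From Propyl to Cyclohexyl: Expected Tolerance of Compound 4

The source may hold more compounds than are shown below. What is called first, only, known or untested is meant among the compounds shown, and "the series" means these compounds.

Of the compounds shown here, three sharing one core have been measured in an ADME assay on MDCK cells (Canis lupus familiaris) for cytotoxicity, read by microscopy, with a stated time of 48 h; a lower number here means that less compound is tolerated, a higher number that more compound is tolerated. Compound 1 `Cc1ccsc1CN[C@@H]1C[C@H]2C[C@@H]([C@H]1C)C2(C)C` gives 10000 nM. Compound 2 `CCCc1ccsc1CN[C@@H]1C[C@H]2C[C@@H]([C@H]1C)C2(C)C` gives 50000 nM, and compound 3 `CCc1csc(CN[C@@H]2C[C@H]3C[C@@H]([C@H]2C)C3(C)C)c1` gives 25000 nM. Among these three numbers compound 2 stands highest; its value and that of compound 3 lie within the scatter of each other, while the gap to compound 1 is larger: a 5.0-fold higher number from compound 1 to compound 2 (0.70 log units; beyond the scatter), a step that comes with ethyl in place of hydrogen on a saturated chain carbon bound to an aromatic carbon.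

Compound 4 `C[C@H]1[C@H](NCc2sccc2C2CCCCC2)C[C@H]2C[C@@H]1C2(C)C` is the next member and has not yet been measured. It differs from compound 2 by cyclohexyl in place of propyl on an aromatic carbon. Among the compounds with values here, the only measured step that touches the same position, from compound 1 to compound 2, raised the number when the chain grew; whether a cyclohexyl group continues that trend or reverses it cannot be read from the three compounds at hand, and compound 3 offers no step to compare. The cautious expectation is therefore a change of no change at the digits printed from compound 2 to compound 4 (within the scatter) in this assay, that is, little movement beyond the scatter. On that basis compound 4 is expected to give about 50000 nM, with a plausible range from 20000 nM to 100000 nM.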

Compound 4, minimum cytotoxic concentration: 1560 nM
Estimate against measurement, compound 4: 32-fold (1.51 log units) above, and the stated range ends above it.
By their numbers in this assay, from the lowest: compound 4; then compound 1; then compounds 3 and 2 (each within the scatter of the next).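

In this assay, this aromatic carbon, two ring bonds from the ring sulfur, does not simply reward a larger group: the rise seen when methyl gave way to propyl does not carry over to cyclohexyl, which brings a 32-fold lower number from compound 2 to compound 4 (1.51 log units; beyond the scatter). Cyclohexyl also falls short of methyl, with a 6.4-fold lower number from compound 1 to compound 4 (0.81 log units; beyond the scatter), so the three groups at this position do not line up in order of their heavy atoms, and the ring-bearing compound 4 lies beyond the scatter of both compounds that carry an open chain or a methyl here. Nothing available explains why this ring reverses the earlier rise.

Going by these compounds, it remains open whether the fall belongs to the ring itself or to the carbon count, a question that a hexyl chain or a cyclopropyl ring on this same carbon would help to settle. On these data alone, it is equally open whether a phenyl ring would behave like cyclohexyl, and whether cyclohexyl would give a similar fall at the ethyl-bearing carbon of compound 3.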